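Removing the acetyl from the ring nitrogen of compound 1

This account rests on a few compounds, and the source may have more. Where it says the series, first, only, none or still open, it means among the compounds named here.

Compound 1 `CC(=O)N1c2ccccc2CCC1C(=O)Nc1ccccc1O`: 50700 nM
Compound 2 `CCC(=O)N1c2ccccc2CCC1C(=O)Nc1ccccc1C(F)(F)F`: > 80000 nM
Compound 3 `CCCCCCCCC(=O)N1c2ccccc2CCC1C(=O)Nc1cc(C(F)(F)F)cc(C(F)(F)F)c1`: 4520 nM

In a functional assay on ACHN cells (Homo sapiens) for cytotoxicity, read by sulforhodamine B assay, with a stated time of 72 h (a higher number here means a weaker inhibitor of growth, a lower number a stronger inhibitor of growth), compound 1 gives 50700 nM, the higher of the two numbers available, standing well above compound 3 at 4520 nM, a gap beyond the scatter. For compound 2 the assay reports only a limit, > 80000 nM, namely (the limit of > 80000 nM in this assay, at which 1 of the 3 values shown sits). Compound 4 `O=C(Nc1ccccc1O)C1CCc2ccccc2N1` differs from compound 1 by hydrogen in place of acetyl on a nitrogen on an aromatic ring in a ring. Within the data shown here, no measured pair isolates this change, so its effect is unknown; compound 4 is expected to stay close to compound 1, with a step of a 1.0-fold lower number from compound 1 to compound 4 (0.01 log units; within the scatter) of no more than the scatter. The estimate for compound 4 is 50000 nM, expected between 15000 nM and 150000 nM.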

Compound 4, concentration for 50% growth inhibition: 3990 nM
For compound 4 the middle estimate is 13-fold (1.10 log units) above the measured one; the measured number lies below the stated range.
By their numbers in this assay, from the lowest: compounds 4 and 3 (each within the scatter of the next); then compound 1. At a limit, above all of these: compound 2.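

In this assay, among these compounds, removing the acetyl from the ring nitrogen gives the first single change that can be read, a 13-fold lower number from compound 1 to compound 4 (1.10 log units; beyond the scatter), so what this nitrogen carries matters greatly for growth inhibition. Compounds 1, 2 and 3 all carry a carbonyl-linked chain there, so they could not show that the free nitrogen retains this stronger growth inhibition. Nothing measured here bears on why the step is so large.

On these data alone, whether a methyl group on this nitrogen would behave like the hydrogen or the acetyl remains open. So does whether removing the chain would have a similar effect in compound 3, with its trifluoromethyl groups.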